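The compounds below may be only part of what the source reports. "The series", "measured", "known", "first", "only" and "open" are said of these compounds alone.

Series notes. Compound 1 `CCCCCN(C)/N=N/c1ccc(C(=O)O)cc1` gives 1.49 in a physicochemical assay for lipophilicity; a lower number here means a more polar compound, a higher number a more lipophilic compound. Compound 2 `CCCCCCCN(C)/N=N/c1ccc(C(=O)O)cc1` gives 2.58 in this assay. Compound 3 `C=CCN(C)/N=N/c1ccc(C(=O)O)cc1` gives 0.32 in this assay. Compound 2 stands highest of the three numbers: the nearest step is a number 1.09 log units higher from compound 1 to compound 2 (beyond the scatter), the furthest is a number 2.26 log units lower from compound 2 to compound 3 (beyond the scatter). Compound 4 `C#CCN(C)/N=N/c1ccc(C(=O)O)cc1` is not yet measured. Its change from compound 2 is ethynyl in place of hexyl on a saturated chain carbon bound to an amine nitrogen. The step that bears on it most directly is a number 2.26 log units lower from compound 2 to compound 3 (beyond the scatter), and a number 1.17 log units lower from compound 1 to compound 3 (beyond the scatter) points the same way, both large. A large fall in this assay is therefore expected. The step is estimated as a number 2.68 log units lower from compound 2 to compound 4 (beyond the scatter). For compound 4 the expected value is -0.1, with a range from -0.7 to 0.5.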

Compound 4, partition coefficient: 0
Beside the measured number, compound 4's estimate is 0.10 log units below it; low and high end bracket the measured number.
By their numbers in this assay, from the lowest: compound 4; then compound 3; then compound 1; then compound 2.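

At this saturated chain carbon bound to an amine nitrogen, ethynyl gives the lowest number of the four compounds in this assay, with a number 2.58 log units lower from compound 2 to compound 4 (beyond the scatter) and a number 1.49 log units lower from compound 1 to compound 4 (beyond the scatter) as the large steps from the longer chains. The new finding is that the two short unsaturated groups can be told apart, since a number 0.32 log units lower from compound 3 to compound 4 (beyond the scatter), a modest step. Nothing on hand accounts for the difference between ethynyl and vinyl.

As far as these compounds go, whether an ethyl group or a nitrile at this place would sit with ethynyl and vinyl or nearer butyl remains open. Chain length and unsaturation therefore stay unseparated in this set.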